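The source may hold more compounds than are shown below. What is called first, only, known or untested is meant among the compounds shown, and "the series" means these compounds.

Working notes on the step from compound 1 to compound 4 within the shared core.

Compound 1 `COc1ccc(/C=C\c2cc(OC)c(OC)c(OC)c2)cc1OCc1ccc(CNC(C)(C)C(=O)O)cc1` is the starting point. In a functional assay on HeLa cells (Homo sapiens) for antiproliferative activity, read by CCK-8 assay, with a stated time of 48 h (a higher number here means a weaker inhibitor, a lower number a stronger inhibitor), compound 1 gives > 10000 nM, which is a limit of the assay and not a number. Compound 1 thus sits at the limit of > 10000 nM in this assay, at which 1 of the 3 values shown sits, so its standing among the numbers shown cannot be fixed more closely.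

Two further members are measured. Compound 2 `COc1ccc(/C=C\c2cc(OC)c(OC)c(OC)c2)cc1OCc1ccc(C=O)cc1`, with a formyl group on the aromatic carbon, gives 4800 nM in this assay. Compound 3 `COc1ccc(/C=C\c2cc(OC)c(OC)c(OC)c2)cc1OCc1ccc(CN2CCCCC2C(=O)O)cc1` gives 14200 nM. The step of an at least 2.0-fold lower number from compound 1 to compound 2 (0.31 log units; beyond the scatter) shows that exchanging the carboxyl-bearing group for formyl lowers the number at least modestly. The step of a 3.0-fold higher number from compound 2 to compound 3 (0.47 log units; beyond the scatter) shows that reintroducing a carboxyl-bearing cyclic amine raises it modestly. The step that the limit leaves unreadable from compound 1 to compound 3 cannot be read.

Compound 4 `COc1ccc(/C=C\c2cc(OC)c(OC)c(OC)c2)cc1OCc1ccc(CN2CC[C@@H](O)C2)cc1` is not yet measured. It differs from compound 1 by 3-hydroxypyrrolidin-1-yl in place of (1-carboxy-1-methylethyl)amino on a saturated chain carbon bound to an aromatic carbon. The change removes the carboxylic acid while keeping a saturated amine on the chain carbon, so the two readable steps both point the same way: loss of the acid goes with a lower number, its return with a higher one. Compound 4 is expected to give 4000 nM, within 1200 nM to 13000 nM. The expected step is an at least 2.5-fold lower number from compound 1 to compound 4 (0.39 log units; beyond the scatter), a modest lowering.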

Compound 4, half-maximal inhibitory concentration: > 10000 nM
Compound 4: only a limit was reported; the forecaster's own chance of this, stated with the estimate: 25%; middle value at least 2.5-fold (0.39 log units) away from the limit.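

Taking the carboxylic acid out of the group on the saturated chain carbon is not enough to reach the level of the formyl compound, since the step to the 3-hydroxypyrrolidin-1-yl compound reads an at least 2.0-fold higher number from compound 2 to compound 4 (0.31 log units; beyond the scatter). Among the compounds shown here, the lower number in this set therefore stays with the formyl group of compound 2 alone, and compound 4, an amine without a carboxyl group, goes against the link between loss of the acid and a lower number that the earlier steps suggested. Compound 4 gives > 10000 nM in this assay, which is a limit of the assay and not a number, so the steps from compound 1 and from compound 3 to compound 4 cannot be read, and more of the series now sits at the limit: the limit of > 10000 nM in this assay, at which 2 of the 4 values shown sit.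

On these data alone, how far compound 1 and compound 4 lie beyond that limit stays open, and with it any order among the amines on the saturated chain carbon. Also open, as far as these compounds go, is whether a hydroxymethyl group on the aromatic carbon, or a plain pyrrolidine or piperidine ring on the chain carbon, would sit with compound 2 or at the limit.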